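The source may report more compounds than this note shows. Statements on the series, on what has been measured and on what is new or still open speak of the compounds shown alone.

Measured in an ADME assay on K562 cells (Homo sapiens) for cytotoxicity, read by MTT assay, with a stated time of 24 h; on this read-out lower numbers stand for higher toxicity in this test and higher numbers for lower toxicity in this test:

compound 1 `Cc1ccc(OC(CCn2ccnc2)c2ccccc2)cc1`: 95900 nM
compound 2 `Clc1ccc(OC(CCn2ccnc2)c2ccccc2)c(Cl)c1`: 121000 nM
compound 3 `Clc1ccc(C(CCn2ccnc2)Oc2ccccc2Cl)cc1`: 205000 nM

Compound 3, at 205000 nM, has a higher number than compound 1, with the gap beyond the scatter, and lies within the scatter of compound 2. These are the only anchors for the next compound.

Compound 4 `Clc1ccc(C(CCn2ccnc2)Oc2c(Cl)cccc2Cl)cc1` follows from compound 3 through one change: chloro in place of hydrogen on an aromatic carbon. This is chloro in place of hydrogen on an aromatic carbon, turning 2-chlorophenyl into 2,6-dichlorophenyl. For the measured compounds named here, no pair of measured compounds differs in one place only, so the series offers no direct precedent for this change. The three values stay close together, running from compound 1 at 95900 nM to compound 3 at 205000 nM. In this assay, no shift beyond the scatter is expected, with a slight lean towards a lower number. The estimated step of a 1.4-fold lower number from compound 3 to compound 4 (0.14 log units; within the scatter) is correspondingly small. For compound 4, the expected value is 150000 nM, with an estimated range from 70000 nM to 300000 nM.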

Compound 4, half-maximal cytotoxic concentration: 135000 nM
Compound 4: middle estimate off by 1.1-fold (0.05 log units), on the high side; the measured number falls inside the stated range.
By their numbers in this assay, from the lowest: compounds 1, 2, 4 and 3 (each within the scatter of the next, the first and the last beyond it).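

In this assay, chloro in place of hydrogen on an aromatic carbon, turning 2-chlorophenyl into 2,6-dichlorophenyl, gives a 1.5-fold lower number from compound 3 to compound 4 (0.18 log units; within the scatter). For the compounds shown here, this is the first pair that differs in one place only, and it shows that this position, ortho to a large group, takes a second chloro without a shift beyond the scatter. Nothing measured here offers an explanation for this result.

From the compounds shown here alone, whether a larger or different group at this position, such as a methoxy group, an amine or a carboxylic acid, would also stay within the scatter of compound 3 remains open. Also open, going by these compounds, is whether the same chloro step would read alike on another compound of the series, or how a longer chain in the shared core would read in this assay.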